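Fluoro to chloro swap: expectation for compound 4

A few compounds are considered here, and "the series" means these few. Any claim that something is new, unique, unknown or untested is made for them only; others in the source may bear on it.

In an ADME assay on Vero 76 cells (Chlorocebus sabaeus) for cytotoxicity, read by MTT assay, with a stated time of 96 h (on this read-out higher numbers stand for lower toxicity in this test and lower numbers for higher toxicity in this test), compound 1 `NS(=O)(=O)c1ccc(N2N=C(c3ccc(Oc4ccccc4)cc3)CC2c2ccccc2F)cc1` gives 96000 nM, the highest of the two plain numbers in the set. Compound 2 `NS(=O)(=O)c1ccc(N2N=C(c3ccccc3)CC2c2ccccc2F)cc1` gives 28000 nM, and the change from compound 1 to compound 2 is a 3.4-fold lower number from compound 1 to compound 2 (0.54 log units; beyond the scatter), with hydrogen in place of phenoxy on an aromatic carbon. Compound 3 `NS(=O)(=O)c1ccc(N2N=C(c3ccc(OCc4ccccc4)cc3)CC2c2ccccc2)cc1` is reported only as a limit, > 100000 nM, and (the limit of > 100000 nM in this assay, at which 1 of the 3 values shown sits).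

Compound 4 `NS(=O)(=O)c1ccc(N2N=C(c3ccc(Oc4ccccc4)cc3)CC2c2ccccc2Cl)cc1` differs from compound 1 by chloro in place of fluoro on an aromatic carbon. For the measured compounds named here, no measured step exchanges one halogen for another at this or any other place; the only measured step, from compound 1 to compound 2, concerns the phenoxy group and says nothing directly about the halogen. The exchange is a single heavy atom for a single heavy atom, with no change in donors, acceptors or charge, so the working expectation is a step within the scatter, a 1.1-fold lower number from compound 1 to compound 4 (0.03 log units; within the scatter), with no preferred direction. Compound 4 is therefore estimated at 90000 nM in this assay, with a range from 40000 nM to 200000 nM, and some chance that the read-out again comes back only as a limit.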

Compound 4, half-maximal cytotoxic concentration: 29000 nM
Compound 4: middle estimate off by 3.1-fold (0.49 log units), on the high side; measured number outside the range, below it.
By their numbers in this assay, from the lowest: compounds 2 and 4 (each within the scatter of the next); then compound 1. At a limit, above all of these: compound 3.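

The 2-fluorophenyl to 2-chlorophenyl exchange is not silent in this assay and gives a 3.3-fold lower number from compound 1 to compound 4 (0.52 log units; beyond the scatter), so a single halogen atom on an aromatic carbon ortho to a large group does move this read-out, towards higher toxicity in this test. The earlier compounds shown here showed a change only at the phenoxy group, with a 3.4-fold lower number from compound 1 to compound 2 (0.54 log units; beyond the scatter), and this result adds the halogen place as a second site of modest sensitivity, with both steps beyond the scatter. The data at hand include no measured property of the two halogens that would account for the new step.

Going by these compounds, whether this step is specific to chloro or continues with bromo, methyl or methoxy at the same place remains open, as does the read-out with hydrogen there. On these data alone, it is also open whether the fluoro to chloro exchange gives a similar step without the phenoxy group, and whether an amine or a carboxylic acid on the outer phenyl ring of the phenoxy group would change the picture.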